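The source may report more compounds than this note shows. Statements on the series, on what has been measured and on what is new or still open speak of the compounds shown alone.

In a functional assay on SK-BR-3 cells (Homo sapiens) for antiproliferative activity (on this read-out lower numbers stand for stronger inhibition and higher numbers for weaker inhibition), compound 2 (`CCCNCCCOc1ccc2cc(NC(=O)c3ccc(O)c(CC=C(C)C)c3)c(=O)oc2c1C`) gives 990 nM and compound 1 (`CCNCCCOc1ccc2cc(NC(=O)c3ccc(O)c(CC=C(C)C)c3)c(=O)oc2c1C`) gives 720 nM, so the two sit within the scatter of each other. Compound 3 (`CCCN(CCC)CCCOc1ccc2cc(NC(=O)c3ccc(O)c(CC=C(C)C)c3)c(=O)oc2c1C`) has propyl in place of hydrogen on an amine nitrogen. For the measured compounds named here, the only measured step that bears on this is a 1.4-fold higher number from compound 1 to compound 2 (0.14 log units; within the scatter), which also adds carbon to the amine chain but is a different change, and it stays within the scatter. Going by the values given here, no measured compound carries two chains on that nitrogen, so the evidence is thin and no clear direction can be expected. The expected step in this assay is a 1.1-fold higher number from compound 2 to compound 3 (0.05 log units; within the scatter), no larger than the scatter. For compound 3 the estimated value is 1100 nM, with an expected range of 450 nM to 2800 nM.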

Compound 3, half-maximal inhibitory concentration: > 50000 nM
Compound 3 was reported as a limit; the forecaster's own chance of this, stated with the estimate: 5%; at least 45-fold (1.65 log units) between middle value and limit.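

In this assay, a second chain on the amine nitrogen has an effect that lengthening the single chain did not: a 1.4-fold higher number from compound 1 to compound 2 (0.14 log units; within the scatter) stayed within the scatter, whereas an at least 50-fold higher number from compound 2 to compound 3 (1.70 log units; beyond the scatter) lies well beyond it. Measured from the ethylamino end, the change gives an at least 69-fold higher number from compound 1 to compound 3 (1.84 log units; beyond the scatter), also beyond the scatter. Compound 3 stands as a limit, not a number: the limit of > 50000 nM in this assay, at which 1 of the 3 values shown sits.

The compounds shown leave open whether any second chain on this nitrogen gives such a step, or only propyl. Dimethylamino and diethylamino at this place would separate those two readings.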